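Compound 1 to compound 4: expected clearance step

This account rests on a few compounds, and the source may have more. Where it says the series, first, only, none or still open, it means among the compounds named here.

Measured so far in an ADME assay on microsomes from liver (Homo sapiens) for metabolic stability, with a stated time of 60 min, tested at 1 mg/mL; a higher number here means faster removal of the compound, a lower number slower removal
compound 1 (`COc1nc2ccc(Br)cc2cc1[C@@H](c1cc(C)c(C)s1)[C@@](O)(CCN(C)C)c1cccc(F)c1`) gives 12 mL.min-1.g-1
compound 2 (`COc1nc2ccc(Br)cc2cc1[C@@H](c1cncc(C)c1)[C@@](O)(CCN(C)C)c1cccc(F)c1`) gives 56 mL.min-1.g-1
compound 3 (`COc1nc2ccc(Br)cc2cc1[C@@H](c1ccnc(OC)c1OC)[C@@](O)(CCN(C)C)c1cccc(OC(F)F)c1`) gives 11 mL.min-1.g-1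

Compound 1 (12 mL.min-1.g-1) sits within the scatter of compound 3 (11 mL.min-1.g-1) and far from compound 2 (56 mL.min-1.g-1). Compound 4 (`COc1cc([C@H](c2cc3cc(Br)ccc3nc2OC)[C@@](O)(CCN(C)C)c2cccc(F)c2)cnc1OC`) differs from compound 1 in one place (5,6-dimethoxypyridin-3-yl in place of 4,5-dimethylthiophen-2-yl on a saturated chain carbon bound to an aromatic carbon and a saturated chain carbon). The closest measured step also replaces 4,5-dimethylthiophen-2-yl at that place, and it is modest (a 4.7-fold higher number from compound 1 to compound 2 (0.67 log units; beyond the scatter)). Compound 3 (11 mL.min-1.g-1) also carries two methoxy groups but differs in more than one place, so it guides less. A smaller step in the same direction is therefore expected in this assay (a 2.3-fold higher number from compound 1 to compound 4 (0.37 log units; beyond the scatter)). The estimated value for compound 4 is 28 mL.min-1.g-1 (expected range 11 mL.min-1.g-1 to 65 mL.min-1.g-1).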

Compound 4, intrinsic clearance in microsomes: 36 mL.min-1.g-1
Beside the measured number, compound 4's estimate is 1.3-fold (0.11 log units) below it, within the range that was stated.
By their numbers in this assay, from the lowest: compounds 3 and 1 (each within the scatter of the next); then compounds 4 and 2 (each within the scatter of the next).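

At the saturated chain carbon bound to an aromatic carbon and a saturated chain carbon, in this assay, 5,6-dimethoxypyridin-3-yl in place of 4,5-dimethylthiophen-2-yl gives a 3.0-fold higher number from compound 1 to compound 4 (0.48 log units; beyond the scatter), so a second pyridinyl group also departs from the 4,5-dimethylthiophen-2-yl value. 5,6-Dimethoxypyridin-3-yl in place of 5-methylpyridin-3-yl gives a 1.6-fold lower number from compound 2 to compound 4 (0.19 log units; within the scatter), so these two pyridinyl groups cannot be told apart here. Nothing available explains either step.

Still open, on these data alone, is whether the ring nitrogen or the ring size tracks with the step from compound 1. Also open, as far as these compounds go, is how a pyridinyl group carrying an amine would behave at this place.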